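Moving the Two Chlorines on the Aromatic Ring

The compounds below may be only part of what the source reports. "The series", "measured", "known", "first", "only" and "open" are said of these compounds alone.

- Compound 1 `Cc1ccc(C(=O)N(C(=S)OCCN2C(=O)c3ccccc3C2=O)c2ccc(C)cc2)cc1`: 83000 nM
- Compound 2 `Cc1ccc(N(C(=O)c2ccc(F)cc2F)C(=S)OCCN2C(=O)c3ccccc3C2=O)cc1`: 20000 nM
- Compound 3 `Cc1ccc(N(C(=O)c2c(Cl)cccc2Cl)C(=S)OCCN2C(=O)c3ccccc3C2=O)cc1`: 22000 nM

In an ADME assay on MT4 cells (Homo sapiens) for cytotoxicity, read by MTT assay (a higher number here means that more compound is tolerated, a lower number that less compound is tolerated), the place of compound 3 is fixed by two steps: a 1.1-fold higher number from compound 2 to compound 3 (0.04 log units; within the scatter), and a 3.8-fold lower number from compound 1 to compound 3 (0.58 log units; beyond the scatter). It thus sits level with compound 2 and apart from compound 1.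

Compound 4 `Cc1ccc(N(C(=O)c2ccc(Cl)c(Cl)c2)C(=S)OCCN2C(=O)c3ccccc3C2=O)cc1` has not yet been measured. Its difference from compound 3 is this: 3,4-dichlorophenyl in place of 2,6-dichlorophenyl on a carbonyl carbon. The two have the same atoms, joined differently, with 3,4-dichlorophenyl in place of 2,6-dichlorophenyl on a carbonyl carbon.

Among the measured compounds shown here, no measured step makes this exact exchange. The closest is the swap of one halogen-bearing phenyl for another, a 1.1-fold higher number from compound 2 to compound 3 (0.04 log units; within the scatter). The two steps away from 4-methylphenyl, a 4.2-fold lower number from compound 1 to compound 2 (0.62 log units; beyond the scatter) and a 3.8-fold lower number from compound 1 to compound 3 (0.58 log units; beyond the scatter), are modest and of similar size, and both end among the halogen-bearing compounds, where compound 4 also belongs. For the measured compounds named here, no measured compound carries 3,4-dichlorophenyl, however, so a move towards compound 1 cannot be excluded.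

No step beyond the scatter is therefore expected in this assay. The expected step is a 1.1-fold higher number from compound 3 to compound 4 (0.06 log units; within the scatter). For compound 4 the estimated value is 25000 nM, with an expected range from 10000 nM to 70000 nM.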

Compound 4, half-maximal cytotoxic concentration: 17000 nM
Beside the measured number, compound 4's estimate is 1.5-fold (0.17 log units) above it; the measured number falls inside the stated range.
By their numbers in this assay, from the lowest: compounds 4, 2 and 3 (each within the scatter of the next); then compound 1.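

In this assay, among the compounds shown here, the exchange of 2,6-dichlorophenyl for 3,4-dichlorophenyl on the carbonyl carbon gives a 1.3-fold lower number from compound 3 to compound 4 (0.11 log units; within the scatter), so relocating the same two chlorines on this ring, which the earlier compounds could not test, does not separate the two compounds. The comparison with the fluorine-bearing ring reads the same way, with a 1.2-fold lower number from compound 2 to compound 4 (0.07 log units; within the scatter) as the step, and the step away from 4-methylphenyl, a 4.9-fold lower number from compound 1 to compound 4 (0.69 log units; beyond the scatter), is again modest, so all three halogen-bearing compounds stand level and only compound 1 stands apart, with no listed compound going against this. Nothing at hand says what lies behind these numbers.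

Going by these compounds, what remains open is whether the separation of compound 1 belongs to the 4-methyl group itself or simply to the absence of halogen, which an unsubstituted phenyl or a 4-methoxyphenyl on the same carbonyl carbon could help to settle. It is also open whether the level seen here would hold for a phenyl carrying a dimethylamino group or a carboxylic acid, since all the groups shown so far are limited to methyl, fluorine and chlorine.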